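Swapping a Dimethylamino for Diethylamino on a Triazole Side Chain

A few compounds are considered here, and "the series" means these few. Any claim that something is new, unique, unknown or untested is made for them only; others in the source may bear on it.

Compound 1 `CN(C)CCn1cnnc1-c1cc(Oc2ccc(NC(=O)Nc3ccc(F)c(Cl)c3)cc2F)ccn1`: 8320 nM
Compound 2 `CN(C)CCn1cnnc1-c1cc(Oc2ccc(NC(=O)Nc3ccc(Cl)cc3Cl)cc2F)ccn1`: 7960 nM

In a functional assay on MDA-MB-231 cells (Homo sapiens) for antiproliferative activity, read by MTT assay, with a stated time of 72 h (a lower number here means a stronger inhibitor, a higher number a weaker inhibitor), compound 1 gives 8320 nM. Among the compounds with values here, the only other measured compound is compound 2, which in this assay gives 7960 nM; the two numbers lie within the scatter of each other, so compound 1 cannot be placed above or below compound 2. Within the data shown here, the single measured step, a 1.0-fold lower number from compound 1 to compound 2 (0.02 log units; within the scatter), changes the aryl group on the urea, not the amine on the chain.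

Compound 3 `CCN(CC)CCn1cnnc1-c1cc(Oc2ccc(NC(=O)Nc3ccc(F)c(Cl)c3)cc2F)ccn1` differs from compound 1 by diethylamino in place of dimethylamino on a saturated chain carbon, two bonds along the chain from an aromatic nitrogen. Among the measured compounds shown here, no measured step touches this part of the shared core, so nothing measured here speaks for or against a change. With no evidence either way, compound 3 is expected to sit close to compound 1, and the estimated step of a 1.0-fold lower number from compound 1 to compound 3 (0.02 log units; within the scatter) is expected to stay within the scatter. The estimate for compound 3 in this assay is 8000 nM, with a range from 3000 nM to 22000 nM.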

Compound 3, half-maximal inhibitory concentration: 34000 nM
Beside the measured number, compound 3's estimate is 4.3-fold (0.63 log units) below it; measured number outside the range, above it.
By their numbers in this assay, from the lowest: compounds 2 and 1 (each within the scatter of the next); then compound 3.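

In this assay, the amine at the end of the side chain turns out to matter: diethylamino in place of dimethylamino on a saturated chain carbon, two bonds along the chain from an aromatic nitrogen, brings a 4.1-fold higher number from compound 1 to compound 3 (0.61 log units; beyond the scatter) and so a modest but real weakening. The earlier step, on the aryl group of the urea, stayed within the scatter, which leaves this chain position as the only place among the compounds shown where a change moves the number. Nothing available here bears on the reason for this shift.

On these data alone, it remains open how a smaller primary amine, or a pyrrolidine or morpholine ring at the end of the same chain, would compare. Also open, as far as these compounds go, is whether diethylamino would shift the number in the same way on the 2,4-dichlorophenyl urea of compound 2.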